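A few compounds are considered here, and "the series" means these few. Any claim that something is new, unique, unknown or untested is made for them only; others in the source may bear on it.

In an ADME assay on Vero cells (Chlorocebus sabaeus) for cytotoxicity, read by MTT assay, with a stated time of 72 h (a lower number here means that less compound is tolerated, a higher number that more compound is tolerated), compound 3 `COc1ccc(/C=C(\C)C(=O)/C=C/c2ccccc2F)cc1` gives 81200 nM and compound 2 `COc1ccc(/C=C(\C)C(=O)/C=C/c2ccccc2Br)cc1` gives 71000 nM, while compound 1 `COc1ccc(/C=C(\C)C(=O)/C=C/c2ccc(Br)cc2)cc1` gives 31200 nM. Compound 3 therefore sits level with compound 2 and clear of compound 1. The next structure, compound 4 `COc1ccc(/C=C(\C)C(=O)/C=C/c2ccc(Cl)cc2)cc1`, differs from compound 3 as follows: 4-chlorophenyl in place of 2-fluorophenyl on a double-bonded chain carbon bound to a double-bonded chain carbon. Among the measured compounds shown here, three measured steps bear on this change. Swapping only the halogen made little difference in a 1.1-fold higher number from compound 2 to compound 3 (0.06 log units; within the scatter), whereas the ring changes gave a 2.3-fold higher number from compound 1 to compound 2 (0.36 log units; beyond the scatter) and a 2.6-fold higher number from compound 1 to compound 3 (0.42 log units; beyond the scatter). The 4-bromophenyl group of compound 1 is the closest match to 4-chlorophenyl, so the last of these is expected to run in reverse. A modest drop is expected, a 2.3-fold lower number from compound 3 to compound 4 (0.35 log units; beyond the scatter). The estimate for compound 4 is 36000 nM, within a range of 19000 nM to 65000 nM.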

Compound 4, half-maximal cytotoxic concentration: 87000 nM
The estimate for compound 4 lay 2.4-fold (0.38 log units) below the measured number; the measured number lies above the stated range.
By their numbers in this assay, from the lowest: compound 1; then compounds 2, 3 and 4 (each within the scatter of the next).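

In this assay, the 4-chlorophenyl ring is not set apart from the 2-fluorophenyl ring, with a 1.1-fold higher number from compound 3 to compound 4 (0.03 log units; within the scatter), nor from the 2-bromophenyl ring, with a 1.2-fold higher number from compound 2 to compound 4 (0.09 log units; within the scatter). Among these four compounds only the 4-bromophenyl ring stands apart, and chloro in place of bromo on that aromatic carbon gives a 2.8-fold higher number from compound 1 to compound 4 (0.45 log units; beyond the scatter), so a halogen at this ring position does not by itself bring the lower number. The data shown offer no explanation for this result.

On these data alone, it remains open how an amine or a carboxylic acid on this ring would compare. A 4-fluorophenyl group would help show whether compound 1 stands alone.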